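The compounds below may be only part of what the source reports. "The series", "measured", "known", "first", "only" and "open" are said of these compounds alone.

Compound 2 `O=C(CCCCCCNC(=O)C(O)(O)C(F)(F)F)Nc1ccncc1` carries a pyridin-4-yl on an amide-type nitrogen, and in a functional assay on HCT-116 cells (Homo sapiens) for inhibition, read by colorimetric assay, with a stated time of 3 days (a lower number here means a stronger inhibitor, a higher number a weaker inhibitor), compound 2 gives 6670 nM, the highest of the two numbers read in this series. Compound 1 `COc1ccc(-c2cnc(NC(=O)CCCCCCNC(=O)C(O)(O)C(F)(F)F)s2)cc1` gives 930 nM in this assay. Compound 3 `OC(O)(c1c(F)c(F)c(-n2cc(-c3ccccc3)nn2)c(F)c1F)C(F)(F)F` reaches only a limit of this assay and gives > 100000 nM. Compound 4 `COc1cccc(NC(=O)CCCCCCNC(=O)C(O)(O)C(F)(F)F)c1` has not yet been measured; it differs from compound 2 by 3-methoxyphenyl in place of pyridin-4-yl on an amide-type nitrogen. Going by the values given here, the single measured neighbour with an oxygen-bearing aromatic ring, compound 1, sits low in this assay with 930 nM. A moderate lowering is therefore expected in this assay, a 2.2-fold lower number from compound 2 to compound 4 (0.35 log units; beyond the scatter), at about the edge of the scatter. Compound 4 is estimated at 3000 nM, with a range from 1000 nM to 10000 nM.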

Compound 4, half-maximal inhibitory concentration: 6110 nM
For compound 4 the middle estimate is 2.0-fold (0.31 log units) below the measured one, within the range that was stated.
By their numbers in this assay, from the lowest: compound 1; then compounds 4 and 2 (each within the scatter of the next). At a limit, above all of these: compound 3.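

In this assay the exchange of pyridin-4-yl for 3-methoxyphenyl on an amide-type nitrogen gives a 1.1-fold lower number from compound 2 to compound 4 (0.04 log units; within the scatter) and so leaves the number unmoved at this position. An oxygen-bearing aromatic ring at this place does not by itself bring the number to the level of compound 1 at 930 nM in this series. Nothing in the evidence at hand bears on this result.

From the compounds shown here alone, what stays open is whether an amine or a carboxylic acid on the phenyl ring would move the number. Going by these compounds, a longer chain in the shared core remains equally open.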